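This account rests on a few compounds, and the source may have more. Where it says the series, first, only, none or still open, it means among the compounds named here.

Working notes on the series. In a functional assay on SW480 cells (Homo sapiens) for cytotoxicity, read by sulforhodamine B assay, with a stated time of 48 h (a higher number here means a weaker inhibitor, a lower number a stronger inhibitor), compound 3 `COc1ccc(/C=C/C(=O)c2cccc(-c3cccc(F)c3)c2)cc1OC` gives 2970 nM. Compound 1 `COc1ccc(/C=C/C(=O)c2ccc(NC(C)=O)c(-c3ccc(F)cc3)c2)cc1OC` gives 5350 nM, within the scatter of the other number, so these two values set no order. The entry for compound 2 `COc1ccc(/C=C/C(=O)c2cccc(-c3cccc(F)c3)c2)cc1O` reads "not determined" (no result reported), which leaves only these two numbers to work from.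

Compound 4 `COc1ccc(/C=C/C(=O)c2cccc(-c3ccc(F)cc3)c2)cc1OC` has not yet been measured. Its difference from compound 3 is 4-fluorophenyl in place of 3-fluorophenyl on an aromatic carbon, meta to a large group. The two compounds have the same atoms, joined differently.

Within the data shown here, no measured pair differs in one place, so the data offer no direct precedent for this change. Compound 1 also bears a 4-fluorophenyl and gives 5350 nM, though it differs from compound 4 elsewhere too. No step beyond the scatter is expected in this assay, and no direction can be favoured. The estimated step, a 1.1-fold higher number from compound 3 to compound 4 (0.05 log units; within the scatter), stays within the scatter. The expected value for compound 4 is 3300 nM, with an estimated range of 1500 nM to 7000 nM.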

Compound 4, half-maximal inhibitory concentration: 6490 nM
Estimate against measurement, compound 4: 2.0-fold (0.29 log units) below, and the stated range covers the measured number.
By their numbers in this assay, from the lowest: compounds 3, 1 and 4 (each within the scatter of the next, the first and the last beyond it).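

In this assay, among these compounds, 4-fluorophenyl in place of 3-fluorophenyl on an aromatic carbon gives a 2.2-fold higher number from compound 3 to compound 4 (0.34 log units; beyond the scatter), the first step beyond the scatter, so this position is sensitive to a modest degree to how the same atoms are joined. Hydrogen in place of acetamido on an aromatic carbon gives a 1.2-fold higher number from compound 1 to compound 4 (0.08 log units; within the scatter), so with 4-fluorophenyl in place, that change shows no readable effect in this assay. No measurement at hand accounts for the step between the two fluorophenyl isomers.

From the compounds shown here alone, whether an unsubstituted phenyl or a chlorophenyl would fall with either fluorophenyl compound remains open. Also open, going by these compounds, is whether an amine or a carboxylic acid in place of acetamido would leave the number as unmoved as hydrogen does.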